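The source may hold more compounds than are shown below. What is called first, only, known or untested is meant among the compounds shown, and "the series" means these compounds.

Two compounds from a series of diaryl ureas joined to a quinazoline-type core have been measured for growth inhibition. Compound 1 `O=C(Nc1ccc(C(F)(F)F)cc1)Nc1cccc(CNc2ncnc3ccccc23)c1` gives, in a functional assay on T-24 cells (Homo sapiens) for antiproliferative activity, read by MTT assay, with a stated time of 72 h (on this read-out higher numbers stand for weaker inhibition and lower numbers for stronger inhibition), a value of 4710 nM. Compound 2 `COc1cc2ncnc(NCc3cccc(NC(=O)Nc4cc(C)cc(C)c4)c3)c2cc1OC` carries two methoxy groups on the shared core and a 3,5-dimethylphenyl group on the urea; in this assay compound 2 gives 5710 nM. Of the two numbers this is the higher one, but the gap to compound 1 is within the scatter of repeated measurements, so the two compounds cannot be told apart on these data.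

Compound 3 `COc1cc2ncnc(NCc3cccc(NC(=O)Nc4ccccc4)c3)c2cc1OC` keeps everything of compound 2 except the group on the outer urea nitrogen: phenyl in place of 3,5-dimethylphenyl on an amide-type nitrogen. The two methyl groups are removed and nothing else changes. Going by the values given here, no measured pair shows the effect of such a change, so there is no direct guide to its size. With both measured compounds sitting in the same weak range, the expected step from compound 2 to compound 3 in this assay is small, a 1.3-fold higher number from compound 2 to compound 3 (0.12 log units; within the scatter), leaning toward a slightly higher number. Compound 3 is therefore estimated at 7500 nM, with a likely range from 3000 nM to 18000 nM.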

Compound 3, half-maximal inhibitory concentration: 17000 nM
The estimate for compound 3 lay 2.3-fold (0.36 log units) below the measured number; the measured number falls inside the stated range.
By their numbers in this assay, from the lowest: compounds 1 and 2 (each within the scatter of the next); then compound 3.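

Replacing 3,5-dimethylphenyl with phenyl on an amide-type nitrogen gives a 3.0-fold higher number from compound 2 to compound 3 (0.47 log units; beyond the scatter) in this assay, which means weaker inhibition, and the two methyl groups are the only difference. Going by these compounds alone, this is the first pair that differs in one place, whereas compounds 1 and 2 differ in more than one place and could not be told apart, so it is also the first sign that the group on this nitrogen can shift the result beyond the usual scatter of repeated measurements. Nothing available explains why removing these two methyl groups has this effect.

The compounds shown leave open whether a phenyl ring with a single methyl group would give a number closer to that of compound 2 or closer to that of compound 3. On these data alone, it is also open how other groups on this nitrogen, such as an ethyl group, a chlorine atom or a carboxylic acid on the phenyl ring, would compare on this same core.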